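This account rests on a few compounds, and the source may have more. Where it says the series, first, only, none or still open, it means among the compounds named here.

Compound 2 `CNCCCCNCCCNC` was tested in a functional assay on L1210 cells (Mus musculus) for inhibition, with a stated time of 48 h; a lower number here means a stronger inhibitor, a higher number a weaker inhibitor. In this assay compound 2 gives only the limit > 100000 nM. Compound 1 `CNCCCNCCCNC` likewise gives only the limit > 100000 nM. Among the measured compounds shown here, the one measured step, a step that the two limits leave unreadable from compound 1 to compound 2, is the step that bears on what follows, yet its size is hidden by the limit of > 100000 nM in this assay, at which 2 of the 2 values shown sit. Compound 3 `CNCCCCNCCCCNC` differs from compound 2 by (methylamino)methyl in place of methylamino on a saturated chain carbon, three bonds along the chain from an amine nitrogen. With both known values sitting at the limit of > 100000 nM in this assay, at which 2 of the 2 values shown sit, no direction can be read, and compound 3 is expected to remain near that limit. Compound 3 is estimated at 150000 nM, in a range from 50000 nM to 500000 nM. The expected step that the limit leaves unreadable from compound 2 to compound 3 is none beyond the scatter.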

Compound 3, half-maximal inhibitory concentration: > 100000 nM
Compound 3 was reported as a limit (the forecaster's own chance of this, stated with the estimate: 85%); the middle value does not contradict the limit.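

Among the compounds shown here, compound 2 and compound 3 both stand only as limits, so no step between them can be read: the limit of > 100000 nM in this assay, at which 3 of the 3 values shown sit. The compounds shown leave open how strongly each inhibits, and whether replacing methylamino with (methylamino)methyl changes inhibition at all.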